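Substituent variation on the five-membered ring: compound 3

This account rests on a few compounds, and the source may have more. Where it says the series, first, only, none or still open, it means among the compounds named here.

The series keeps one core and varies the group on an aromatic carbon of the five-membered aromatic ring with two nitrogen atoms, which also bears a 4-methoxyphenyl group. Compound 1 `COCc1nc2c(NC(C3CC3)C3CC3)nc(C)nc2n1-c1ccc(OC)cc1` gives 157 nM in a functional assay on CHO cells for antagonist activity at corticotropin-releasing factor receptor 1 (Homo sapiens), read by cAMP accumulation; a lower number here means a stronger inhibitor, a higher number a weaker inhibitor. Compound 2 `COc1ccc(-n2c(CC3CC3)nc3c(NC(C4CC4)C4CC4)nc(C)nc32)cc1` gives 308 nM in this assay. Among the measured compounds shown here, compound 2 has the highest of the two numbers measured so far, but the step of a 2.0-fold higher number from compound 1 to compound 2 (0.29 log units; within the scatter) is within the scatter, so the two compounds cannot be set in order on these data.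

Compound 3 `COc1ccc(-n2c(C3CC(F)(F)C3)nc3c(NC(C4CC4)C4CC4)nc(C)nc32)cc1` has not yet been measured in this assay. It differs from compound 2 by 3,3-difluorocyclobutyl in place of cyclopropylmethyl on an aromatic carbon. For the measured compounds named here, the only measured step at this position is a 2.0-fold higher number from compound 1 to compound 2 (0.29 log units; within the scatter), a small one. Going by the values given here, no measured step shows what a four-membered ring or fluorine does at this place. The expected step is therefore a 1.0-fold lower number from compound 2 to compound 3 (0.01 log units; within the scatter) in this assay, with no direction beyond the scatter. Compound 3 is estimated at 300 nM, with a range from 100 nM to 900 nM.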

Compound 3, inhibition constant: 261 nM
Beside the measured number, compound 3's estimate is 1.1-fold (0.06 log units) above it; the measured number falls inside the stated range.
By their numbers in this assay, from the lowest: compounds 1, 3 and 2 (each within the scatter of the next).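

Compound 3 brings a four-membered non-aromatic ring and two fluorine atoms to this aromatic carbon between two ring nitrogen atoms, and in this assay the exchange for cyclopropylmethyl gives a 1.2-fold lower number from compound 2 to compound 3 (0.07 log units; within the scatter). Set against methoxymethyl, the same group gives a 1.7-fold higher number from compound 1 to compound 3 (0.22 log units; within the scatter), so all three groups shown at this position lie within the scatter of one another, even with 6 heavy atoms in place of 4 and a ring of a different size. No measurement at hand offers an explanation for this result.

All three compounds shown carry uncharged groups here without hydrogen-bond donors, so it stays open whether an amine, a carboxylic acid or a longer chain at this place would move the number beyond the scatter. The contributions of the four-membered ring and of the fluorine atoms also remain unseparated, and a plain cyclobutyl group would be needed to tell them apart, with the 4-methoxyphenyl group and the rest of the shared core held constant.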